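Amide nitrogen substituent and kinetic solubility

The compounds below may be only part of what the source reports. "The series", "measured", "known", "first", "only" and "open" are said of these compounds alone.

Measured compounds:
compound 1 `NCc1csc(NC(=O)c2cnn[nH]2)n1` — > 100 ug/mL
compound 2 `NCc1csc(NC(=O)c2cnnn2Cc2ccccc2)n1` — 50 ug/mL
compound 3 `CC(C)(C)c1cc(C(=O)Nc2ccccc2)n(Cc2ccccc2)n1` — 1.6 ug/mL

In a physicochemical assay for solubility, read by nephelometry, measured as kinetic solubility, at pH 6.5 (on this read-out higher numbers stand for higher solubility and lower numbers for lower solubility), compound 3 gives 1.6 ug/mL, the lowest of the two numbers shown. Compound 2 gives 50 ug/mL in this assay. For compound 1 the reading > 100 ug/mL is a limit of this assay, not a number; the limit of > 100 ug/mL in this assay, at which 1 of the 3 values shown sits, marks where it sits.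

Compound 4 `CN(C)Cc1csc(NC(=O)c2cc(C(C)(C)C)nn2Cc2ccccc2)n1` differs from compound 3 by 4-((dimethylamino)methyl)-1,3-thiazol-2-yl in place of phenyl on an amide-type nitrogen. Among the compounds with values here, the only measured step, an at least 2.0-fold lower number from compound 1 to compound 2 (0.30 log units; that floor lies within the scatter), concerns a different change and does not bear directly on this one. The expectation therefore rests on the values: compound 2, which carries the thiazolyl group with its aminomethyl chain, gives 50 ug/mL, well above compound 3. Compound 4 is thus expected to show a 9.4-fold higher number from compound 3 to compound 4 (0.97 log units; beyond the scatter), an estimated 15 ug/mL with a range from 4 ug/mL to 60 ug/mL.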

Compound 4, solubility: 25 ug/mL
Beside the measured number, compound 4's estimate is 1.7-fold (0.22 log units) below it; measured number inside the range.
By their numbers in this assay, from the lowest: compound 3; then compounds 4 and 2 (each within the scatter of the next). At a limit, above all of these: compound 1.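

Within the data shown here, compound 3 and compound 4 give the first read of a change on the amide-type nitrogen, as the earlier step concerned benzyl on an aromatic nitrogen. In this assay, 4-((dimethylamino)methyl)-1,3-thiazol-2-yl in place of phenyl gives a 16-fold higher number from compound 3 to compound 4 (1.19 log units; beyond the scatter), so this position strongly affects the read-out. Nothing measured here accounts for the size of this step.

The compounds shown leave open whether the step belongs to the ring or to its side chain. A bare 1,3-thiazol-2-yl, or a phenyl carrying the same (dimethylamino)methyl chain, would separate the two.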